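Working notes: aryl variation on the ring amine nitrogen

The source may hold more compounds than are shown below. What is called first, only, known or untested is meant among the compounds shown, and "the series" means these compounds.

Compound 1 `CC1(c2ccccc2)CC(=O)N(CC(=O)N2CCN(c3ccc(Cl)cc3)CC2)C1=O`: "not active" (no number reported)
Compound 2 `CC1(c2ccccc2)CC(=O)N(CC(=O)N2CCN(c3cccc(Cl)c3)CC2)C1=O`: 300 mg/kg
Compound 3 `COc1cccc(N2CCN(C(=O)CN3C(=O)CC(C)(c4ccccc4)C3=O)CC2)c1`: "not active" (no number reported)

In a functional assay on the whole organism (strain CD-1) with Mus musculus as the target, in the maximal electroshock model, with a stated time of 2 h (on this read-out higher numbers stand for an effect only at larger amounts of compound and lower numbers for an effect already at smaller amounts), compound 3 is recorded as "not active" (no number reported) and carries no number. Compound 1 is recorded the same way in this assay, as "not active" (no number reported), so two of the three measured compounds give no numerical read-out; only compound 2 yields a figure in this assay, namely 300 mg/kg. Within the data shown here, compound 3 therefore stands among the entries without a number, with nothing to rank it against compound 1 and no measured step from it to any other compound.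

The next compound, compound 4 `CC1(c2ccccc2)CC(=O)N(CC(=O)N2CCN(c3ccccc3Cl)CC2)C1=O`, differs from compound 3 in one place: 2-chlorophenyl in place of 3-methoxyphenyl on an amine nitrogen in a ring. Since compound 3 has no number, no step size in this assay can be stated from these data; the sole figure in the series, that of compound 2, offers a rough anchor for where an active result would land. Compound 4 is expected, if it does give a number, to fall near 300 mg/kg, in the range 100 mg/kg to 600 mg/kg, with a substantial chance that it too is recorded without a number.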

Compound 4, minimum effective dose: "not active" (no number reported)
Compound 4: no number reported; no gap can be computed for the estimate.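

Compound 3 and compound 4 are both recorded without a number in this assay, so no step can be read between them. The compounds shown leave open whether 2-chlorophenyl in place of 3-methoxyphenyl alters the minimum effective dose at all. No evidence bears on this result.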